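A few compounds are considered here, and "the series" means these few. Any claim that something is new, unique, unknown or untested is made for them only; others in the source may bear on it.

Compound 1 `COc1cccc(N2CCN(C(=O)C(C)N3C(=O)CCC3=O)CC2)c1` and compound 2 `CCC(C(=O)N1CCN(c2ccccc2)CC1)N1C(=O)CCC1=O` share the same core, carrying a substituted phenyl on the ring nitrogen. In a functional assay on the whole organism (strain Swiss) with Mus musculus as the target, in the maximal electroshock model, with a stated time of 1 h, at a dose of 100 mg/kg by the intraperitoneal route (a higher number here means a stronger effect of the compound at the dose given, a lower number a weaker effect), compound 1 gives 0% and compound 2 gives 0%; compound 1 thus stands level with compound 2 within the scatter, and neither shows any effect at the dose tested. Compound 3 `CC(C(=O)N1CCN(c2ccccc2F)CC1)N1C(=O)CCC1=O` differs from compound 1 by 2-fluorophenyl in place of 3-methoxyphenyl on an amine nitrogen in a ring. Going by the values given here, with no step between measured compounds to go by, the expected step is a number 5 percentage points higher from compound 1 to compound 3 (within the scatter), which lies within the scatter. Compound 3 is therefore expected to give 5%, between 0% and 25%.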

Compound 3, a percentage reported as activity, at one dose (the size of the read-out at that dose, not a potency): 0%
Compound 3: the middle estimate sits 5 percentage points above what was measured; the range from low to high includes it.
By their numbers in this assay, from the lowest: compounds 1, 2 and 3 (each within the scatter of the next).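

In this assay, replacing 3-methoxyphenyl with 2-fluorophenyl on the amine nitrogen in the ring gives no change at the digits printed from compound 1 to compound 3 (within the scatter). Exchanging this group, with its different substituent, therefore does not bring out an effect at the dose given, but with no effect at either end of the step, the result cannot show how much this position matters. Nothing measured here bears on the reason for this result. The compounds shown leave open whether a trifluoromethyl on the phenyl, or a pyridine ring in its place, would give any effect in this assay.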